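This account rests on a few compounds, and the source may have more. Where it says the series, first, only, none or still open, it means among the compounds named here.

Of the compounds shown here, three have so far been measured in an ADME assay on MT4 cells (Homo sapiens) for cytotoxicity, read by MTT assay; on this read-out higher numbers stand for lower toxicity in this test and lower numbers for higher toxicity in this test. Compound 1 `O=C1c2ccccc2C(=O)N1CCOC(=S)N(C(=O)c1ccccc1[N+](=O)[O-])c1ccc(Cl)cc1` gives 21000 nM, compound 2 `Cc1ccc(N(C(=O)c2ccccc2[N+](=O)[O-])C(=S)OCCN2C(=O)c3ccccc3C2=O)cc1` gives 100000 nM, and compound 3 `O=C1c2ccccc2C(=O)N1CCOC(=S)N(C(=O)c1cccc(F)c1F)c1ccc(Cl)cc1` gives 58000 nM. Compound 2 therefore shows the highest of the three numbers; its gap to compound 3 lies within the scatter, while the step of a 4.8-fold higher number from compound 1 to compound 2 (0.68 log units; beyond the scatter) lies beyond it. Compound 4 `Cc1ccc(N(C(=O)c2ccc(Cl)cc2Cl)C(=S)OCCN2C(=O)c3ccccc3C2=O)cc1` differs from compound 2 by 2,4-dichlorophenyl in place of 2-nitrophenyl on a carbonyl carbon. Going by the values given here, the only measured step at the same carbonyl carbon, a 2.8-fold higher number from compound 1 to compound 3 (0.44 log units; beyond the scatter), also replaced the 2-nitrophenyl with another ring and moved the number modestly upward, so compound 4 is expected to show a comparable upward step, a 1.3-fold higher number from compound 2 to compound 4 (0.11 log units; within the scatter), though compound 2 already sits at the top of the measured range. Compound 4 is accordingly estimated at 130000 nM, within a range of 50000 nM to 320000 nM.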

Compound 4, half-maximal cytotoxic concentration: 49000 nM
For compound 4 the middle estimate is 2.7-fold (0.42 log units) above the measured one; measured number outside the range, below it.
By their numbers in this assay, from the lowest: compound 1; then compounds 4, 3 and 2 (each within the scatter of the next, the first and the last beyond it).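

In this assay the change at this carbonyl carbon now runs downward, a 2.0-fold lower number from compound 2 to compound 4 (0.31 log units; beyond the scatter), whereas the earlier change at the same place ran upward, a 2.8-fold higher number from compound 1 to compound 3 (0.44 log units; beyond the scatter). Replacing the 2-nitrophenyl therefore has no single direction across these compounds, and here the number moves towards higher toxicity in this test. Nothing available explains this difference in direction. From the compounds shown here alone, the two steps differ in both the entering ring and the methyl or chloro on the aromatic carbon, so it remains open which of these sets the direction. Also open, going by these compounds, is how an aminophenyl or a plain phenyl on this carbonyl carbon would read.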